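Pyrrolidine in place of the nitrile chain

A few compounds are considered here, and "the series" means these few. Any claim that something is new, unique, unknown or untested is made for them only; others in the source may bear on it.

Going by the values given here, compound 1 `C[n+]1ccn(CCCCC#N)c1/C=N/O` gives -2.8 in a physicochemical assay for lipophilicity (a lower number here means a more polar compound, a higher number a more lipophilic compound), the lowest of the two numbers so far, while compound 2 `COC(=O)CCCCCn1cc[n+](C)c1/C=N/O` gives -2.21. Among the compounds with values here, the only measured step, a number 0.59 log units higher from compound 1 to compound 2 (beyond the scatter), concerns a different change at a different place on the chain. Compound 3 `C[n+]1ccn(CCN2CCCC2)c1/C=N/O` differs from compound 1 by pyrrolidin-1-yl in place of 2-cyanoethyl on a saturated chain carbon, two bonds along the chain from an aromatic nitrogen. Within the data shown here, no measured step bears directly on this change, so the expectation rests on little. For compound 3 the step of a number 0.40 log units lower from compound 1 to compound 3 (beyond the scatter) is expected, a small fall or none beyond the scatter. Compound 3 is therefore estimated at -3.2, with a range from -4 to -2.5.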

Compound 3, distribution coefficient: -2.73
Compound 3: the middle estimate sits 0.47 log units below what was measured, and the stated range covers the measured number.
By their numbers in this assay, from the lowest: compounds 1 and 3 (each within the scatter of the next); then compound 2.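

In this assay the exchange gives a number 0.07 log units higher from compound 1 to compound 3 (within the scatter) and so does not separate the two groups on a saturated chain carbon, two bonds along the chain from an aromatic nitrogen. The printed values therefore place pyrrolidin-1-yl, with its five-membered non-aromatic ring, level with the ring-free 2-cyanoethyl with its triple bond. No measurement at hand gives a reason for this result. On these data alone, whether a piperidine, a morpholine or a dimethylamino group would read the same at this place remains open. So does the reading of pyrrolidine on a longer chain.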